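A few compounds are considered here, and "the series" means these few. Any claim that something is new, unique, unknown or untested is made for them only; others in the source may bear on it.

Measured compounds and their values in a functional assay on HeLa cells (Homo sapiens) for cytotoxicity, read by MTT assay, with a stated time of 48 h; a lower number here means a stronger inhibitor, a higher number a weaker inhibitor:
- compound 1 `CCOC(=O)c1c(-c2cc3ccc(OC)cc3oc2=O)nn(-c2ccccc2)c1C(=O)OCC`: 140000 nM
- compound 2 `CCOC(=O)c1c(-c2cc3ccc(OC)cc3oc2=O)nn(-c2cccc(Cl)c2)c1C(=O)OCC`: 205000 nM
- compound 3 `CCOC(=O)c1c(-c2cc3ccc(OCC=C(C)C)cc3oc2=O)nn(-c2ccccc2)c1C(=O)OCC`: 130000 nM

In this assay compound 3, with 130000 nM, sits together with compound 1 and compound 2: the gaps between the three numbers are all within the usual scatter, so no one of them can be called stronger or weaker than the others. Compound 4 `CCOC(=O)c1c(-c2cc3ccc(OCC=C(C)C)cc3oc2=O)nn(-c2cccc(Cl)c2)c1C(=O)OCC` has not been measured yet. It differs from compound 3 in one place: chloro in place of hydrogen on an aromatic carbon. The same change has already been made once among the measured compounds, from compound 1 to compound 2, and there it gave a 1.5-fold higher number from compound 1 to compound 2 (0.17 log units; within the scatter), a shift within the scatter. On that single precedent, the step from compound 3 to compound 4 is expected to be of similar size and direction, a slightly higher number at most, and not beyond the scatter: a 1.5-fold higher number from compound 3 to compound 4 (0.16 log units; within the scatter). The number for compound 4 in this assay is therefore estimated at 190000 nM, with a range from 100000 nM to 360000 nM.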

Compound 4, half-maximal inhibitory concentration: 110000 nM
Estimate against measurement, compound 4: 1.7-fold (0.24 log units) above; measured number inside the range.
By their numbers in this assay, from the lowest: compounds 4, 3, 1 and 2 (each within the scatter of the next).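

In this assay, the change from phenyl to 3-chlorophenyl has now been read on a second core, where it gives a 1.2-fold lower number from compound 3 to compound 4 (0.07 log units; within the scatter), so on neither core does chloro at this place move the number beyond the scatter, and the two steps agree within their own scatter: the same change on two cores in this assay, a 1.5-fold higher number (0.17 log units; within the scatter) from compound 1 to compound 2 and a 1.2-fold lower number (0.07 log units; within the scatter) from compound 3 to compound 4, 1.7-fold (0.24 log units) apart, within the scatter of two such steps.
Among these compounds, the 2-methylprop-1-en-1-yl change, read for the first time on the 3-chlorophenyl compounds, gives a 1.9-fold lower number from compound 2 to compound 4 (0.27 log units; within the scatter) and behaves the same way on both cores: the same change on two cores in this assay, a 1.1-fold lower number (0.03 log units; within the scatter) from compound 1 to compound 3 and a 1.9-fold lower number (0.27 log units; within the scatter) from compound 2 to compound 4, 1.7-fold (0.24 log units) apart, within the scatter of two such steps.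
Neither change, alone or combined, separates the four compounds in this assay.

From the compounds shown here alone, whether an amine or a carboxylic acid in place of the chloro would move the number beyond the scatter stays open. The same question stands for a longer chain in place of the 2-methylprop-1-en-1-yl.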